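Swapping Chloro for Bromo on a Phenoxy Side Chain

The compounds below may be only part of what the source reports. "The series", "measured", "known", "first", "only" and "open" are said of these compounds alone.

Compound 2, `NC1=NC2(CCSCC2)N(OCCCOc2cccc(Cl)c2)C(N)=N1`: 88.8%
Compound 1, `COc1ccc(OCCCON2C(N)=NC(N)=NC23CCOCC3)cc1`: "not determined" (no result reported)
Compound 3, `NC1=NC2(CCOCC2)N(OCCCOc2ccc(Cl)cc2)C(N)=N1`: "not determined" (no result reported)

Three compounds share a common core carrying a chain that ends in a substituted phenoxy group. Only one of them has a number: in an assay on isolated protein for inhibition of Dihydrofolate reductase (Homo sapiens), read by spectrophotometry, using NADPH, with stated times of 5 s and 6 min, tested at 50 uM (on this read-out lower numbers stand for a weaker effect and higher numbers for a stronger effect at the one concentration tested), compound 2 gives 88.8%. Compound 1 gives "not determined" (no result reported) in this assay. Compound 3 gives "not determined" (no result reported) in this assay. Among the measured compounds shown here, compound 2 therefore stands alone, and no comparison between measured compounds can be drawn from these data.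

The step of interest leads from compound 2 to compound 4, `NC1=NC2(CCSCC2)N(OCCCOc2cccc(Br)c2)C(N)=N1`. The two differ in one place only: bromo in place of chloro on an aromatic carbon. Everything else, including the sulfur-containing ring of the core and the three-carbon chain, is unchanged.

For the measured compounds named here, with no measured pair to calibrate the effect of this exchange, the expectation rests on the small size of the change: one halogen is replaced by another of the same count. The step from compound 2 to compound 4 is therefore expected to be small, a number 1.8 percentage points lower from compound 2 to compound 4 (within the scatter), which is within the usual scatter of this assay rather than a real shift in either direction. Compound 4 is estimated to give 87% in this assay, with a range from 72% to 96%.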

Compound 4, a percentage reported as inhibition, at one concentration (the size of the read-out at that concentration, not a potency): 86.5%
Estimate against measurement, compound 4: 0.5 percentage points above; the range from low to high includes it.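

In this assay, among the compounds shown here, the exchange of chloro for bromo gives a number 2.3 percentage points lower from compound 2 to compound 4 (within the scatter), and this is the first pair here in which two measured compounds can be compared directly. Until now, compound 2 stood alone, with nothing to show whether its read-out depended on the identity of the halogen; this pair shows that 3-chlorophenoxy and 3-bromophenoxy cannot be told apart at this position at the one concentration tested, although a reading at one concentration is not a potency. No supporting data are available to explain this result.

Going by these compounds, the pair covers only these two halogens on a single core, so it remains open whether an amine, a carboxylic acid or a methyl group on this aromatic carbon, or a longer chain between the core and the phenoxy group, would give a similar read-out. On these data alone, it also remains open whether the exchange of chloro for bromo would read the same on another core, and compound 3, which has a different core, gives "not determined" (no result reported) and so offers no test of this.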